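This account rests on a few compounds, and the source may have more. Where it says the series, first, only, none or still open, it means among the compounds named here.

Compound 1 `COC(=O)CNC(=O)C(CSCc1ccc(Br)cc1)NC(=O)CCC(N)C(=O)O`: in a functional assay on K562 cells (Homo sapiens) for cytotoxicity (a higher number here means a weaker inhibitor, a lower number a stronger inhibitor), a limit, > 50 uM.
Compound 2 `O=C(O)CNC(=O)C(CSCc1ccc(Br)cc1)NC(=O)CCC(NC(=O)OCc1ccccc1)C(=O)O`: in this assay a limit, > 50 uM.
Compound 3 `COC(=O)CNC(=O)C(CSCc1ccc(Br)cc1)NC(=O)CCC(NC(=O)OCc1ccccc1)C(=O)O`: in this assay a limit, > 50 uM.

Compound 3 stands only as a limit, and so do both of its neighbours, which is why a step that the two limits leave unreadable from compound 1 to compound 3 and a step that the two limits leave unreadable from compound 2 to compound 3 cannot be read; all three rest on (the limit of > 50 uM in this assay, at which 3 of the 3 values shown sit). Compound 4 `NC(=O)CNC(=O)C(CSCc1ccc(Br)cc1)NC(=O)CCC(NC(=O)OCc1ccccc1)C(=O)O` differs from compound 3 by amino in place of methoxy on a carbonyl carbon. Going by the values given here, no measured step speaks to this change, and nothing among the three compounds has yet moved off the limit, so no step beyond the scatter is expected in this assay. Compound 4 is therefore estimated at 60 uM, between 20 uM and 200 uM. That estimate amounts to a step that the limit leaves unreadable from compound 3 to compound 4, most likely reported again as a limit.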

Compound 4, concentration for 50% inhibition: > 50 uM
Compound 4 gave a limit, no number; the forecaster's own chance of this, stated with the estimate: 85%; the middle value does not contradict the limit.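

Compound 4 is also only a limit, so neither its step from compound 3 nor its step from compound 2 can be read: the limit of > 50 uM in this assay, at which 4 of the 4 values shown sit. The compounds shown leave open which change, if any, would bring a measurable value in this assay.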